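Cyclobutylmethyl for Cyclopentyl: an Isomeric Step in Stability

The source may report more compounds than this note shows. Statements on the series, on what has been measured and on what is new or still open speak of the compounds shown alone.

Compound 1 `CNc1nc(OC2CCCC2)nc2c1ncn2Cc1c(F)cccc1F`: 190 uL/min
Compound 2 `CN(Cc1ccc2c(c1)CCCO2)c1nnc(-c2ccc(-c3ccccc3Cl)cc2)o1`: 19 uL/min

In an ADME assay on cells (Hepatocyte, Rattus norvegicus) for metabolic stability (a lower number here means slower removal, a higher number faster removal of the compound), compound 1 gives 190 uL/min, the highest of the two numbers. Compound 2, built on a different core, gives 19 uL/min, a gap beyond the scatter. Compound 3 `CNc1nc(OCC2CCC2)nc2c1ncn2Cc1c(F)cccc1F` keeps the atoms of compound 1 joined differently: cyclobutylmethyl in place of cyclopentyl on an oxygen on an aromatic ring. Going by the values given here, no measured pair shows this change, so the expected step of a 1.1-fold lower number from compound 1 to compound 3 (0.05 log units; within the scatter) is modest, not beyond the scatter, in either direction. Compound 3 is therefore estimated at 170 uL/min, within a range from 80 uL/min to 360 uL/min.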

Compound 3, intrinsic clearance in a liver preparation (reported as CLH), per the amount of preparation that the assay uses in the Hepatocyte assay: 160 uL/min
Estimate against measurement, compound 3: 1.1-fold (0.03 log units) above; measured number inside the range.
By their numbers in the Hepatocyte assay, from the lowest: compound 2; then compounds 3 and 1 (each within the scatter of the next).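

In the Hepatocyte assay putting cyclobutylmethyl in place of cyclopentyl on an oxygen on an aromatic ring gives a 1.2-fold lower number from compound 1 to compound 3 (0.07 log units; within the scatter) so this rearrangement of the same carbon atoms leaves the clearance read-out indistinguishable. In a physicochemical assay for lipophilicity, at pH 7.4 (on this read-out lower numbers stand for lower lipophilicity and higher numbers for higher lipophilicity), compound 1 gives 4.3 and compound 3 gives 4.4 which also lie within the scatter of each other. Nothing available explains why the two groups read alike. Still open, on these data alone, is whether an amine or a longer chain on this oxygen would move the number in the Hepatocyte assay beyond the scatter.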